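The compounds below may be only part of what the source reports. "The series", "measured", "known", "first", "only" and "open" are said of these compounds alone.

Measured in a functional assay on DLD-1 cells (Homo sapiens) for cytotoxicity, read by resazurin assay, with a stated time of 48 h; a higher number here means that more compound is needed for the effect, a lower number that less compound is needed:
- Compound 1 `COc1ccc(S(=O)(=O)Nc2ccc3oc(-c4ccc(NC(=O)c5ccc(Cl)s5)cc4)nc3c2)cc1`: 4600 nM
- Compound 2 `COc1ccc(S(=O)(=O)Nc2ccc3oc(-c4ccc(NS(=O)(=O)c5cc(Br)ccc5OC)cc4)nc3c2)cc1`: 15000 nM

In this assay, compound 2 gives 15000 nM, the higher of the two numbers. Compound 3 `COc1ccc(S(=O)(=O)Nc2ccc3oc(-c4ccc(NS(=O)(=O)c5cc(F)ccc5OC)cc4)nc3c2)cc1` has not yet been measured. It differs from compound 2 by a single change: fluoro in place of bromo on an aromatic carbon. Among the compounds with values here, only one measured step is available, a 3.3-fold higher number from compound 1 to compound 2 (0.51 log units; beyond the scatter). It is modest and exchanges a whole group on a nitrogen, so it bears only loosely on a swap of fluoro in place of bromo on an aromatic carbon. Within the data shown here, no measured pair shows what such a swap does. Among the measured compounds shown here, a step smaller than the one from compound 1 is therefore expected, with no step beyond the scatter and no firm direction in this assay. The expected step is a 1.3-fold lower number from compound 2 to compound 3 (0.10 log units; within the scatter). For compound 3 the estimate is 12000 nM, with an expected range of 5000 nM to 30000 nM.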

Compound 3, half-maximal effective concentration: 18000 nM
Compound 3: middle estimate off by 1.5-fold (0.18 log units), on the low side, within the range that was stated.
By their numbers in this assay, from the lowest: compound 1; then compounds 2 and 3 (each within the scatter of the next).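

In this assay the swap of bromo for fluoro, para to the methoxy group, gives a 1.2-fold higher number from compound 2 to compound 3 (0.08 log units; within the scatter) and so leaves the number where it was: at this place on the ring, the two halogens cannot be told apart. The exchange of the whole group on the nitrogen also holds with fluoro in place, with a 3.9-fold higher number from compound 1 to compound 3 (0.59 log units; beyond the scatter) as its size, so the gap from compound 1 does not depend on bromo. Nothing measured here explains why these two halogens read alike.

The compounds shown leave open whether a group other than a halogen at this place, such as an amine or a carboxylic acid, would shift the number beyond the scatter. They also do not separate the change from carbonyl to sulfonyl from the change of ring on that nitrogen, since compound 1 differs from compound 2 and compound 3 in both at once.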